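Replacing 4-methoxybenzyl with 3-methylbut-2-en-1-yl

This account rests on a few compounds, and the source may have more. Where it says the series, first, only, none or still open, it means among the compounds named here.

In a functional assay on K562 cells (Homo sapiens) for inhibition, read by fluorescence, with a stated time of 72 h (a higher number here means a weaker inhibitor of growth, a lower number a stronger inhibitor of growth), compound 1 `COc1ccc(Nc2nc(N[C@H]3CC[C@H](N)CC3)nc3c2ncn3CCC(C)C)c(OC)c1` gives 5500 nM, compound 2 `CC(C)CCn1cnc2c(Nc3ccc(Cl)cc3)nc(N[C@H]3CC[C@H](N)CC3)nc21` gives 1800 nM and compound 3 `COc1ccc(Cn2cnc3c(Nc4cccc(Cl)c4)nc(N[C@H]4CC[C@H](N)CC4)nc32)cc1` gives 2800 nM. Compound 3 lies within the scatter of both, while the gap between the other two is a 3.1-fold lower number from compound 1 to compound 2 (0.49 log units; beyond the scatter). Compound 4 `CC(C)=CCn1cnc2c(Nc3cccc(Cl)c3)nc(N[C@H]3CC[C@H](N)CC3)nc21` changes compound 3 as follows: 2-methylprop-1-en-1-yl in place of 4-methoxyphenyl on a saturated chain carbon bound to an aromatic nitrogen. In other words, 3-methylbut-2-en-1-yl stands in place of 4-methoxybenzyl. Going by the values given here, that one measured step concerns a different group, so no measured step tests this change directly. Compound 2, also without a ring in this group but different elsewhere too, gives 1800 nM, within the scatter of compound 3. No step beyond the scatter is therefore expected in this assay. The expected change is a 1.3-fold lower number from compound 3 to compound 4 (0.10 log units; within the scatter). For compound 4 the estimated value is 2200 nM, with an expected range from 900 nM to 5500 nM.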

Compound 4, concentration for 50% growth inhibition: 3500 nM
The estimate for compound 4 lay 1.6-fold (0.20 log units) below the measured number; the measured number falls inside the stated range.
By their numbers in this assay, from the lowest: compounds 2, 3, 4 and 1 (each within the scatter of the next, the first and the last beyond it).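

In this assay, going by these compounds alone, changing only this group gives a 1.3-fold higher number from compound 3 to compound 4 (0.10 log units; within the scatter). Within the data shown here, this is the first direct comparison at the saturated chain carbon bound to an aromatic nitrogen, and it shows that 4-methoxyphenyl and 2-methylprop-1-en-1-yl cannot be told apart here, even though the entering group has no ring. Nothing measured here bears on the reason for this result.

The compounds shown leave open whether a carboxylic acid or a cyclohexylmethyl group in place of 3-methylbut-2-en-1-yl would also stay within the scatter.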